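Replacing tert-butoxy in compound 1 with a dichlorophenylamino group

This account rests on a few compounds, and the source may have more. Where it says the series, first, only, none or still open, it means among the compounds named here.

Compound 1 `CC(C)(C)OC(=O)NCCNc1cc(/C=C/c2ccccc2)nc2ccccc12` carries tert-butoxy on a carbonyl carbon. In an ADME assay on J774 cells (Mus musculus) for cytotoxicity, read by MTT assay, with a stated time of 48 h (on this read-out higher numbers stand for weaker inhibition and lower numbers for stronger inhibition), compound 1 gives 6600 nM, the lowest number of the three measured compounds. Compound 2 `O=C(CN1CCCC1)NCCNc1cc(/C=C/c2ccccc2)nc2ccccc12` gives 12500 nM and compound 3 `CN1CCN(CC(=O)NCCNc2cc(/C=C/c3ccccc3)nc3ccccc23)CC1` gives 34000 nM; the step of a 1.9-fold higher number from compound 1 to compound 2 (0.28 log units; within the scatter) stays within the scatter, while a 5.2-fold higher number from compound 1 to compound 3 (0.71 log units; beyond the scatter) and a 2.7-fold higher number from compound 2 to compound 3 (0.43 log units; beyond the scatter) are modest. Compound 4 `O=C(CNc1ccc(Cl)cc1Cl)NCCNc1cc(/C=C/c2ccccc2)nc2ccccc12` differs from compound 1 by ((2,4-dichlorophenyl)amino)methyl in place of tert-butoxy on a carbonyl carbon. Both measured replacements of tert-butoxy gave higher numbers, yet each brought in pyrrolidin-1-yl or 4-methylpiperazin-1-yl, whereas the entering group of compound 4 holds an aromatic ring, so those steps guide only loosely. Compound 4 is therefore expected to show a 1.0-fold lower number from compound 1 to compound 4 (0.01 log units; within the scatter), no larger than the scatter, with an estimate of 6500 nM between 2000 nM and 20000 nM.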

Compound 4, half-maximal inhibitory concentration: > 50000 nM
Compound 4: no number, only a limit; the forecaster's own chance of this, stated with the estimate: 5%; middle value at least 7.6-fold (0.88 log units) from the limit.
By their numbers in this assay, from the lowest: compounds 1 and 2 (each within the scatter of the next); then compound 3. At a limit, above all of these: compound 4.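

In this assay compound 4 gives no number, only a limit: the limit of > 50000 nM in this assay, at which 1 of the 4 values shown sits. On this carbonyl carbon, ((2,4-dichlorophenyl)amino)methyl in place of tert-butoxy gives an at least 7.5-fold higher number from compound 1 to compound 4 (0.87 log units; beyond the scatter), so a group holding an aromatic ring can move the read-out well beyond the scatter. Swapping in (2,4-dichlorophenyl)amino on the saturated chain carbon gives an at least 4.0-fold higher number from compound 2 to compound 4 (0.60 log units; beyond the scatter), but an at least 1.4-fold higher number from compound 3 to compound 4 (0.16 log units; that floor lies within the scatter) leaves no firm order for that pair.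

As far as these compounds go, the actual number for compound 4 remains open. So does the part played by the two chlorines, which a plain phenylamino group in the same place would test.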